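The source may report more compounds than this note shows. Statements on the series, on what has been measured and on what is new or still open speak of the compounds shown alone.

Measured in an in vitro ADME assay on microsomes from liver (Homo sapiens) for metabolic stability; on this read-out lower numbers stand for slow clearance and higher numbers for fast clearance:
- Compound 1 `CC(C)NC(=O)[C@H]1CC[C@@H](n2/c(=N/C(=O)c3cc(F)cc(Cl)c3)[nH]c3ccc(CN4CCC(C(C)(C)O)CC4)cc32)CC1`: 83 mL.min-1.g-1
- Compound 2 `C=CCNS(=O)(=O)c1cccc(C(=O)/N=c2\[nH]c3cc(CN4CCCCC4)ccc3n2[C@H]2CC[C@@H](CO)CC2)c1`: 100 mL.min-1.g-1
- Compound 3 `CC(C)NC(=O)[C@H]1CC[C@@H](n2/c(=N/C(=O)c3ccc(F)c(F)c3)[nH]c3ccc(CN4CCC(C(C)(C)O)CC4)cc32)CC1`: 60 mL.min-1.g-1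

Compound 3, at 60 mL.min-1.g-1, lies within the usual scatter of both compound 1 and compound 2, so these three numbers cannot be ranked. Compound 4 `CC(C)NC(=O)[C@H]1CC[C@@H](n2/c(=N/C(=O)c3ccc(F)c(Cl)c3)[nH]c3ccc(CN4CCC(C(C)(C)O)CC4)cc32)CC1` differs from compound 3 by one swap, chloro in place of fluoro on an aromatic carbon. This turns 3,4-difluorophenyl into 3-chloro-4-fluorophenyl. Among the measured compounds shown here, only one measured step also changes the halogens on this phenyl group, a 1.4-fold lower number from compound 1 to compound 3 (0.14 log units; within the scatter), and it stayed within the scatter. A similarly small change is therefore expected in this assay, with no clear direction. The estimated step is a 1.3-fold higher number from compound 3 to compound 4 (0.10 log units; within the scatter). Compound 4 is expected at 75 mL.min-1.g-1, within an estimated range of 40 mL.min-1.g-1 to 130 mL.min-1.g-1.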

Compound 4, intrinsic clearance in microsomes: 83 mL.min-1.g-1
The estimate for compound 4 lay 1.1-fold (0.04 log units) below the measured number; the measured number falls inside the stated range.
By their numbers in this assay, from the lowest: compounds 3, 1, 4 and 2 (each within the scatter of the next).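

In this assay, chloro in place of fluoro at this position gives a 1.4-fold higher number from compound 3 to compound 4 (0.14 log units; within the scatter) and adds a second halogen swap on this phenyl group that stays small. With 3-chloro-4-fluorophenyl in place of 3-chloro-5-fluorophenyl, the result is no change at the digits printed from compound 1 to compound 4 (within the scatter) and the three halogen patterns remain unranked. Nothing available here offers an explanation for these numbers. On these data alone, the phenyl groups compared carry only fluoro and chloro, so it stays open whether a methoxy group or a nitrile at this position would give a step beyond the scatter.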